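The source may hold more compounds than are shown below. What is called first, only, known or untested is meant among the compounds shown, and "the series" means these compounds.

Measured compounds in a functional assay on HSG cells (Homo sapiens) for cytotoxicity; a lower number here means that less compound is tolerated, a higher number that more compound is tolerated:
- compound 1 `COc1cc(/C=C2\CC/C(=C\c3ccc([N+](=O)[O-])cc3)C2=O)cc(OC)c1OC`: > 400000 nM, a limit of the assay, not a number
- compound 2 `COc1cc(/C=C2\Cc3ccccc3/C(=C\c3ccc([N+](=O)[O-])cc3)C2=O)ccc1O`: 5800 nM
- compound 3 `COc1cc(/C=C2\CCC/C(=C\c3ccc([N+](=O)[O-])cc3)C2=O)ccc1O`: 11000 nM

Compound 2 holds the lowest of the two numbers in this assay. Its nearest neighbour is compound 3, whose value lies within the usual scatter of it, so no order can be read between compound 2 and compound 3. The third value, that of compound 1, is a limit only (the limit of > 400000 nM in this assay, at which 1 of the 3 values shown sits).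

Compound 4 `COc1ccc(/C=C2\Cc3ccccc3/C(=C\c3ccc([N+](=O)[O-])cc3)C2=O)cc1` is not yet measured. It differs from compound 2 in one place: 4-methoxyphenyl in place of 4-hydroxy-3-methoxyphenyl on a double-bonded chain carbon bound to a double-bonded ring carbon. No measured pair shows this change, and no cause can be assigned to any of the steps among the measured compounds. The expectation for compound 4 therefore rests on compound 2 alone, whose value in this assay is 5800 nM.

The step from compound 2 to compound 4 in this assay is expected to be small, a 1.2-fold higher number from compound 2 to compound 4 (0.08 log units; within the scatter), not clearly beyond the scatter in either direction. Compound 4 is thus estimated at 7000 nM, with a range from 2500 nM to 25000 nM.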

Compound 4, half-maximal cytotoxic concentration: 47000 nM
Beside the measured number, compound 4's estimate is 6.7-fold (0.83 log units) below it; the measured number lies above the stated range.
By their numbers in this assay, from the lowest: compounds 2 and 3 (each within the scatter of the next); then compound 4. At a limit, above all of these: compound 1.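

In this assay, the group on a double-bonded chain carbon bound to a double-bonded ring carbon now has its first single-place reading: 4-methoxyphenyl in place of 4-hydroxy-3-methoxyphenyl gives an 8.1-fold higher number from compound 2 to compound 4 (0.91 log units; beyond the scatter). The earlier compounds shown here differed in more than one place and could not isolate this position, whereas this pair shows that a change in this group alone can move the number beyond the scatter. No measurement at hand gives a cause for this step.

For the compounds shown here, the single swap changes the group as a whole, so it remains open whether the same step would appear with a 4-hydroxyphenyl group or on the core of compound 3. On these data alone, how an amine or a carboxylic acid on the aromatic ring of this group would read also remains open.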